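Substituent swap on the aryl ring: fluoro for methoxy

The source may report more compounds than this note shows. Statements on the series, on what has been measured and on what is new or still open speak of the compounds shown alone.

Two compounds of the series have numbers in an assay on HepG2 cells for agonist activity at nuclear receptor subfamily 1 group I member 3 (Homo sapiens), read by a luciferase reporter, with a stated time of 23 h; on this read-out higher numbers stand for an effect only at larger amounts of compound and lower numbers for an effect already at smaller amounts. Compound 1 `CC(C)c1ccc(-c2nc3sccn3c2/C=N/OCc2ccc(Cl)c(Cl)c2)cc1` gives 590 nM. Compound 2 `COc1ccc(-c2nc3sccn3c2/C=N/OCc2ccc(Cl)c(Cl)c2)cc1` gives 490 nM. Of the two, compound 2 holds the lower number, but the gap is small: the step of a 1.2-fold lower number from compound 1 to compound 2 (0.08 log units; within the scatter), where methoxy replaces isopropyl on an aromatic carbon, is within the scatter. Among the measured compounds shown here, on the numbers so far, compound 2 therefore stands level with compound 1.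

Compound 3 `Fc1ccc(-c2nc3sccn3c2/C=N/OCc2ccc(Cl)c(Cl)c2)cc1` is the next variation of the same position. For the measured compounds named here, the change fluoro in place of methoxy on an aromatic carbon is the only one between compound 2 and compound 3. Going by the values given here, the one step that bears on it is a 1.2-fold lower number from compound 1 to compound 2 (0.08 log units; within the scatter): a change of the group at this aromatic carbon from isopropyl to methoxy left the number essentially unchanged. Among the compounds with values here, no measured step shows a fluoro group at this site, so the expectation rests on that single comparison. In this assay the step from compound 2 to compound 3 is expected to be a 1.1-fold higher number from compound 2 to compound 3 (0.03 log units; within the scatter), that is, nothing beyond the scatter. Compound 3 is accordingly estimated at 520 nM in this assay, with a range from 200 nM to 1400 nM.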

Compound 3, half-maximal effective concentration: 670 nM
The estimate for compound 3 lay 1.3-fold (0.11 log units) below the measured number; low and high end bracket the measured number.
By their numbers in this assay, from the lowest: compounds 2, 1 and 3 (each within the scatter of the next).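

Fluoro gives a third reading at the aromatic carbon para to a large group: in this assay, a 1.4-fold higher number from compound 2 to compound 3 (0.14 log units; within the scatter), and a 1.1-fold higher number from compound 1 to compound 3 (0.06 log units; within the scatter), with both steps within the scatter. Together with the earlier swap of isopropyl for methoxy, this means that all three groups shown at this site give numbers within the scatter of one another, and the hydrogen-bond acceptor counted for methoxy leaves in compound 3 without a step beyond the scatter. Nothing available explains this flat response at the site.

On these data alone, whether the number stays level with a different kind of group here, such as an amine, a carboxylic acid or a longer chain, remains open. As far as these compounds go, all three compounds share everything outside this site, so the response of the number to changes elsewhere in the molecule also remains open.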